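This account rests on a few compounds, and the source may have more. Where it says the series, first, only, none or still open, it means among the compounds named here.

Measured compounds so far:
compound 1, `O=C1NC(O)(CCn2cc(-c3ccccc3)nn2)C(OCc2ccccc2)=C1OCc1ccccc1`: 53400 nM
compound 2, `O=C1O/C(=C\Cn2cc(C3=CCCCC3)nn2)C(OCc2ccccc2)=C1OCc1ccccc1`: > 100000 nM

Among the measured compounds shown here, in a functional assay on HCT-116 cells (Homo sapiens) for antiproliferative activity, read by MTT assay, with a stated time of 24 h (on this read-out lower numbers stand for stronger inhibition and higher numbers for weaker inhibition), compound 1 gives 53400 nM and is the only compound with a number rather than a limit. Compound 2 reaches only a limit in this assay, > 100000 nM, and no number can be read from it. The evidence on limits is the limit of > 100000 nM in this assay, at which 1 of the 2 values shown sits. For the measured compounds named here, there is therefore no measured step of one structural change on which to lean, and compound 1 alone sets the level of the series.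

Compound 3, `Cc1ccc(-c2cn(CCC3(O)NC(=O)C(OCc4ccccc4)=C3OCc3ccccc3)nn2)cc1`, differs from compound 1 by methyl in place of hydrogen on an aromatic carbon. The shared core, its two benzyloxy substituents and the triazole-bearing chain are kept; only a methyl enters on the phenyl of the triazole substituent, para to a large group.

With a single number in hand, the step from compound 1 to compound 3 is expected to stay within the usual scatter, a 1.2-fold lower number from compound 1 to compound 3 (0.07 log units; within the scatter), with no clear direction. Compound 3 is estimated at 45000 nM in this assay, within a range of 18000 nM to 100000 nM.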

Compound 3, half-maximal inhibitory concentration: 74300 nM
Compound 3: the middle estimate sits 1.7-fold (0.22 log units) below what was measured, within the range that was stated.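

In this assay the phenyl of the triazole substituent now has its first reading for a single structural change, methyl in place of hydrogen on an aromatic carbon, para to a large group: a 1.4-fold higher number from compound 1 to compound 3 (0.14 log units; within the scatter). The earlier compounds shown here offered no such step, and this one shows that going from phenyl to 4-methylphenyl leaves compound 1 and compound 3 indistinguishable in this assay, so this added methyl gives no sign of moving the read-out in either direction. No measurement shown bears on any cause for this step.

As far as these compounds go, a single methyl says little about other groups at this place on the phenyl, and it remains open whether a fluorine, a methoxy group, an amine or a carboxylic acid there would give a step beyond the scatter. Also open, from the compounds shown here alone, is how the read-out would respond to a longer chain to the triazole, or to replacing either benzyloxy substituent on the shared core with a smaller group such as methoxy.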